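The compounds below may be only part of what the source reports. "The series", "measured", "known", "first", "only" and "open" are said of these compounds alone.

Values measured in a functional assay on A-431 cells (Homo sapiens) for cytotoxicity; a lower number here means that less compound is needed, a higher number that more compound is needed for the effect:
Compound 1 `COC1=C(C)C(=O)/C(=C(O)/C=C/c2ccc(Br)cc2)C(=O)C1(C)C`: 9 ug/mL
Compound 2 `COC1=C(C)C(=O)/C(=C(O)/C=C/c2ccccc2OC)C(=O)C1(C)C`: 6.6 ug/mL
Compound 3 `COC1=C(C)C(=O)/C(=C(O)/C=C/c2ccccc2C)C(=O)C1(C)C`: 5.2 ug/mL

These three compounds share a core and differ only in the group carried at the end of the chain. Compound 3 has the lowest number on paper, but it cannot be separated from the other two, since both of its gaps lie within the usual scatter of repeated measurements: a 1.7-fold lower number from compound 1 to compound 3 (0.24 log units; within the scatter) and a 1.3-fold lower number from compound 2 to compound 3 (0.10 log units; within the scatter).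

Compound 4 `COC1=C(C)C(=O)/C(=C(O)/C=C/c2ccco2)C(=O)C1(C)C` keeps the same core, with furan-2-yl in place of 2-methylphenyl on a double-bonded chain carbon bound to a double-bonded chain carbon.

Within the data shown here, no measured compound carries furan-2-yl, so the evidence is indirect. The closest guide is how far the number moved when this same group was exchanged before. Those exchanges gave a 1.4-fold lower number from compound 1 to compound 2 (0.13 log units; within the scatter), along with the two steps above, and none of them went beyond the scatter. A step of similar size is therefore expected here, with no clear direction in this assay. The estimated step is a 1.3-fold higher number from compound 3 to compound 4 (0.10 log units; within the scatter), which stays within the scatter. The expected value for compound 4 is 6.5 ug/mL, with an estimated range from 3 ug/mL to 14 ug/mL.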

Compound 4, concentration for half-maximal effect: 14.7 ug/mL
Compound 4: middle estimate off by 2.3-fold (0.35 log units), on the low side, outside the stated range (above it).
By their numbers in this assay, from the lowest: compounds 3, 2, 1 and 4 (each within the scatter of the next, the first and the last beyond it).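

In this assay, among these compounds, the group on a double-bonded chain carbon bound to a double-bonded chain carbon now proves able to move the number beyond the scatter, which no step among the first three compounds did: furan-2-yl gives (a 2.8-fold higher number from compound 3 to compound 4 (0.45 log units; beyond the scatter)) against 2-methylphenyl and (a 2.2-fold higher number from compound 2 to compound 4 (0.35 log units; beyond the scatter)) against 2-methoxyphenyl. The exchange does not set furan-2-yl apart from every phenyl group, however, and compound 1 goes against any such pattern: the step against 4-bromophenyl (a 1.6-fold higher number from compound 1 to compound 4 (0.21 log units; within the scatter)) stays within the scatter. Nothing in the data shown explains why the number shifts with this exchange.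

Because furan-2-yl is the only five-membered ring shown, the compounds leave open whether these steps go with the smaller ring or with its oxygen, a question that thiophen-2-yl, with sulfur in place of that oxygen, and an unsubstituted phenyl could help to separate. Also open, as far as these compounds go, is how this assay responds to a phenyl ring carrying an amine or a carboxylic acid at this end of the chain.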